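Inverting one chain stereocentre of a limit-bound prostanoid

The source may hold more compounds than are shown below. What is called first, only, known or untested is meant among the compounds shown, and "the series" means these compounds.

The series comprises four stereoisomers sharing one skeleton. Compound 1 `CCCC[C@](C)(OC)[C@H](O)/C=C/C1[C@H](O)C[C@H](O)[C@@H]1C/C=C\CCCC(=O)OC` sits at a limit in a functional assay on the whole organism (stomach) with Rattus norvegicus as the target (a higher number here means that more compound is needed for the effect, a lower number that less compound is needed), giving > 2 mg/kg. Compound 2 `CCCC[C@@](C)(OC)[C@H](O)/C=C/C1[C@H](O)C[C@H](O)[C@@H]1C/C=C\CCCC(=O)OC` gives 1.5 mg/kg in this assay. Compound 3 `CCCC[C@](C)(OC)[C@@H](O)/C=C/C1[C@H](O)C[C@H](O)[C@@H]1C/C=C\CCCC(=O)OC` is also reported only as a limit in this assay, at > 4 mg/kg. Thus compound 3 stands at the weaker edge of what this assay resolves, with no number of its own; the step of an at least 2.6-fold higher number from compound 2 to compound 3 (0.42 log units; beyond the scatter) is the only one readable against it, while a step that the two limits leave unreadable from compound 1 to compound 3 cannot be sized.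

Compound 4 `CCCC[C@@](C)(OC)[C@@H](O)/C=C/C1[C@H](O)C[C@H](O)[C@@H]1C/C=C\CCCC(=O)OC` differs from compound 3 as follows: the two compounds have the same atoms and bonds; at least one stereo element is drawn with a configuration in one of them and without one in the other: 1 of 8 stereo elements differ; a stereocentre at a saturated chain carbon is drawn S in compound 3 and R in compound 4. The same kind of inversion, at a stereocentre at a saturated chain carbon, separates compound 1 from compound 2, where an at least 1.3-fold lower number from compound 1 to compound 2 (0.12 log units; that floor lies within the scatter). That step points toward a lower number but is sized only by a floor within the scatter. Compound 4 is therefore expected to need somewhat less than compound 3, with the step of an at least 1.3-fold lower number from compound 3 to compound 4 (0.12 log units; that floor lies within the scatter) estimated. Compound 4 is expected to give about 3 mg/kg in this assay, within 1 mg/kg to 10 mg/kg.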

Compound 4, dose for 50% inhibition: > 2 mg/kg
Compound 4: only a limit was reported; the forecaster's own chance of this, stated with the estimate: 45%; the middle value does not contradict the limit.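

Compound 4 is reported only as a limit in this assay, at > 2 mg/kg, and it shares that limit with compound 1: the limit of > 2 mg/kg in this assay, at which 2 of the 4 values shown sit. The one step that can be read is an at least 1.3-fold higher number from compound 2 to compound 4 (0.12 log units; that floor lies within the scatter), so inverting this saturated chain carbon alone is not shown to move the number beyond the scatter. The steps to compound 4 from compound 1 and from compound 3 cannot be read, since limits stand at both ends of each.

Where compounds 1, 3 and 4 actually lie beyond their limits stays open, and with it whether either inversion changes the dose needed at all. Also open, as far as these compounds go, is how a carboxylic acid in place of the methyl ester, or a longer chain, would read in this assay.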